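The source may hold more compounds than are shown below. What is called first, only, known or untested is meant among the compounds shown, and "the series" means these compounds.

Working notes on the series

Compound 1 `C/C(=N\O)c1ccc2[nH]c(-c3ccccc3)nc2c1` is the unsubstituted member. In an ADME assay on MDBK cells (Bos taurus) for cytotoxicity, read by MTT assay, with a stated time of 96 h (on this read-out lower numbers stand for higher toxicity in this test and higher numbers for lower toxicity in this test), compound 1 gives > 100000 nM, which is a limit of the test and not a number; it sits at the limit of > 100000 nM in this assay, at which 1 of the 3 values shown sits. Compound 2 `C/C(=N\O)c1ccc2[nH]c(-c3ccc(Cl)cc3)nc2c1` differs from compound 1 by chloro in place of hydrogen on an aromatic carbon, and in this assay compound 2 gives 37000 nM; the step is an at least 2.7-fold lower number from compound 1 to compound 2 (0.43 log units; beyond the scatter). Compound 3 `C/C(=N\NC(N)=S)c1ccc2c(c1)nc(-c1ccccc1)n2C1CCCCC1` carries a different core; how it differs from compound 1 is not broken down here. In this assay compound 3 gives 24000 nM, and this value and that of compound 2 lie within the scatter of each other. Compound 4 `C/C(=N\NC(N)=S)c1ccc2c(c1)nc(-c1ccc(Cl)cc1)n2C1CCCCC1` differs from compound 3 by chloro in place of hydrogen on an aromatic carbon, the same change as between compound 1 and compound 2, at the same place. For compound 4 the expected step is a 2.0-fold lower number from compound 3 to compound 4 (0.30 log units; within the scatter), resting on the measured step of an at least 2.7-fold lower number from compound 1 to compound 2 (0.43 log units; beyond the scatter). Compound 4 is accordingly estimated at 12000 nM, expected between 5000 nM and 30000 nM.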

Compound 4, half-maximal cytotoxic concentration: > 100000 nM
Compound 4 was reported as a limit; the forecaster's own chance of this, stated with the estimate: 3%; middle value at least 8.3-fold (0.92 log units) away from the limit.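

Chloro in place of hydrogen gives an at least 4.1-fold higher number from compound 3 to compound 4 (0.61 log units; beyond the scatter) in this assay, so on these two cores the change does not carry over from one to the other. The two steps point in opposite directions: the same change on two cores in this assay, an at least 2.7-fold lower number (0.43 log units; beyond the scatter) from compound 1 to compound 2 and an at least 4.1-fold higher number (0.61 log units; beyond the scatter) from compound 3 to compound 4, at least 11-fold (1.05 log units) apart, beyond the scatter of two such steps

Each step has a limit at one end, so neither gives an exact size, and two pairs do not show what sets the direction or how the change would behave on a further core.

Open, going by these compounds, is whether another group at the same place, such as fluoro, methoxy or an amine, would follow the step to compound 2 or the step to compound 4. Also open, on these data alone, is which part of the difference between the core of compound 1 and the core of compound 3 goes with the reversal.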